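Phenyl in Place of Hydrogen on an Aromatic Nitrogen

The source may hold more compounds than are shown below. What is called first, only, known or untested is meant among the compounds shown, and "the series" means these compounds.

Measured compounds:
compound 1 `COc1cccc(CNC(=O)c2c[nH]c3cc(-c4cn[nH]c4)ccc23)c1` < 1 nM
compound 2 `COc1cccc(CN(C)C(=O)c2c[nH]c3cc(-c4cn[nH]c4)ccc23)c1` 19 nM

Of the compounds shown here, two have been measured in an assay on isolated protein for inhibition of Rho-associated protein kinase 1 (Homo sapiens); a higher number here means a weaker inhibitor, a lower number a stronger inhibitor. Compound 1 `COc1cccc(CNC(=O)c2c[nH]c3cc(-c4cn[nH]c4)ccc23)c1` gives < 1 nM in this assay, and this is a limit of the assay rather than a number (the limit of < 1 nM in this assay, at which 1 of the 2 values shown sits). Compound 2 `COc1cccc(CN(C)C(=O)c2c[nH]c3cc(-c4cn[nH]c4)ccc23)c1` gives 19 nM in this assay. Among the compounds with values here, the single measured step, an at least 19-fold higher number from compound 1 to compound 2 (1.27 log units; beyond the scatter), shows how strongly the amide hydrogen matters. Compound 1 therefore stands only as a limit, with no exact number known.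

Compound 3 `COc1cccc(CNC(=O)c2cn(-c3ccccc3)c3cc(-c4cn[nH]c4)ccc23)c1` differs from compound 1 by phenyl in place of hydrogen on an aromatic nitrogen. Within the data shown here, the measured step touched the amide-type nitrogen, not the aromatic nitrogen, so no measured step bears directly on this change; the measured data give no guidance on substitution at this aromatic nitrogen. A moderate loss in this assay is expected, smaller than the step to compound 2. Compound 3 is estimated at 5 nM, between 0.5 nM and 50 nM, a step of an at least 5.0-fold higher number from compound 1 to compound 3 (0.69 log units; beyond the scatter) that is expected.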

Compound 3, half-maximal inhibitory concentration: 21 nM
Compound 3: middle estimate off by 4.2-fold (0.62 log units), on the low side; measured number inside the range.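

Putting phenyl in place of hydrogen on the aromatic nitrogen gives an at least 21-fold higher number from compound 1 to compound 3 (1.32 log units; beyond the scatter) in this assay. Within the data shown here, the earlier step touched only the amide-type nitrogen, so this is the first measured sign that the aromatic nitrogen of the five-membered ring is also sensitive to change, with a large loss for this one group. Compound 1 stands at a limit of the assay and not at a number, so the step has only a lower bound and its full size is unknown: the limit of < 1 nM in this assay, at which 1 of the 3 values shown sits.

The compounds shown do not tell whether the loss belongs to phenyl itself or would follow any replacement of that hydrogen. A methyl, a benzyl or a longer chain ending in an amine on the same nitrogen would separate these two readings.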